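Methoxy substitution across two weak cores

The compounds below may be only part of what the source reports. "The series", "measured", "known", "first", "only" and "open" are said of these compounds alone.

Compound 1 `O=C(NNc1nc2ccccc2nc1Cc1ccccc1)c1ccccc1`: 360000 nM
Compound 2 `COc1ccc(C(=O)NNc2nc3ccccc3nc2Cc2ccccc2)cc1`: 920000 nM
Compound 3 `O=C(Cn1c(=O)c(Cc2ccccc2)nc2ccccc21)N/N=C/c1ccccc1`: 880000 nM

Going by the values given here, in an assay for inhibition of Amine oxidase [flavin-containing] B (Bos taurus), read by fluorescence, with a stated time of 60 min (a lower number here means a stronger inhibitor, a higher number a weaker inhibitor), compound 1 gives 360000 nM, and the only counted change among the measured compounds, (methoxy in place of hydrogen on an aromatic carbon), yields a 2.6-fold higher number from compound 1 to compound 2 (0.41 log units; beyond the scatter). Compound 3 carries a different core; the difference between the two cores is not broken down here. In this assay compound 3 gives 880000 nM, which lies within the scatter of the value of compound 2.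

Compound 4 `COc1ccc(/C=N/NC(=O)Cn2c(=O)c(Cc3ccccc3)nc3ccccc32)cc1` has not yet been measured. It differs from compound 3 by methoxy in place of hydrogen on an aromatic carbon, the same change as that from compound 1 to compound 2, at the same kind of place. Resting on that one step, compound 4 is expected to show a step of about a 2.3-fold higher number from compound 3 to compound 4 (0.36 log units; beyond the scatter) in this assay, because the value of compound 2 sits at 920000 nM after the same change. Among the compounds with values here, with only one example of the change on another core, the range is wide. Compound 4 is estimated at 2000000 nM, between 700000 nM and 6000000 nM.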

Compound 4, half-maximal inhibitory concentration: 82000 nM
Compound 4: middle estimate off by 24-fold (1.39 log units), on the high side; the whole stated range lies above it.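

In this assay, methoxy in place of hydrogen gave an 11-fold lower number from compound 3 to compound 4 (1.03 log units; beyond the scatter), so phenyl to 4-methoxyphenyl moved the number the opposite way from the same change on the core of compound 1. The two steps differ in direction and size, and the gap between them lies beyond the scatter: the same change on two cores in this assay, a 2.6-fold higher number (0.41 log units; beyond the scatter) from compound 1 to compound 2 and an 11-fold lower number (1.03 log units; beyond the scatter) from compound 3 to compound 4, 27-fold (1.44 log units) apart, beyond the scatter of two such steps. This shows that, for these two pairs, the step seen on one core did not carry over to the other, but with a single example of the change on each core it does not show why, nor what would happen on any further core.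

The compounds shown leave open whether the reversal is particular to methoxy or would also appear with another group at the same place, such as a hydroxyl, an amine or a carboxylic acid. They also leave open whether a longer chain in place of the methoxy would follow compound 4 or compound 2.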